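Working notes: chloro in place of fluoro on compound 3

This account rests on a few compounds, and the source may have more. Where it says the series, first, only, none or still open, it means among the compounds named here.

Measured so far in an ADME assay on NPC-TW01 cells (Homo sapiens) for cytotoxicity, read by MTT assay; a lower number here means a stronger inhibitor, a higher number a weaker inhibitor (each value a limit of the assay):
- compound 1 `C/C(COc1cccc2ccccc12)=N\O`: > 50000 nM (limit)
- compound 2 `O/N=C(\COc1cccc2ccccc12)c1ccccc1`: > 50000 nM (limit)
- compound 3 `O/N=C(\COc1cccc2ccccc12)c1ccc(F)cc1`: > 50000 nM (limit)

In this assay compound 3 gives only a limit, > 50000 nM, and no number. Going by the values given here, it has company there: the record shows (the limit of > 50000 nM in this assay, at which 3 of the 3 values shown sit), so no measured compound yet has a number to stand on.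

Compound 4 `O/N=C(\COc1cccc2ccccc12)c1ccc(Cl)cc1` is not yet measured. It carries chloro in place of fluoro on an aromatic carbon, para to a large group, so that 4-fluorophenyl becomes 4-chlorophenyl: chloro in place of fluoro on an aromatic carbon.

The closest measured change is a step that the two limits leave unreadable from compound 2 to compound 3, which is fluoro in place of hydrogen on an aromatic carbon. That change offers no size to carry over and no direction. With compound 3 at the limit of > 50000 nM, the working expectation is no step beyond the scatter in this assay, and a further limit is the likeliest report. The estimated outcome is a number no higher from compound 3 to compound 4 (the limit leaves the size open), with no direction favoured. Compound 4 is estimated at 50000 nM, with an expected range from 20000 nM to 100000 nM in the same read-out.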

Compound 4, half-maximal inhibitory concentration: > 50000 nM
Compound 4: only a limit was reported (the forecaster's own chance of this, stated with the estimate: 75%); the middle value lies on the limit itself.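

In this assay compound 4 gives > 50000 nM, a limit and not a number. No step can be read between compound 4 and compound 3 or compound 2, and the series stays at a single limit: the limit of > 50000 nM in this assay, at which 4 of the 4 values shown sit.

The compounds shown leave open whether hydrogen, fluoro or chloro on this aromatic carbon makes any difference in this assay.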